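Notes on 3-hydroxyphenyl to 3-methylphenyl in the series

The source may hold more compounds than are shown below. What is called first, only, known or untested is meant among the compounds shown, and "the series" means these compounds.

Measured in a functional assay on PC-3 cells (Homo sapiens) for inhibition, read by MTT assay; a higher number here means a weaker inhibitor, a lower number a stronger inhibitor:
- compound 1 `COc1c(N2CCN(C)CC2)c(F)cc2c(=O)c(C(=O)N/N=C\c3cc(Br)ccc3O)cn(C3CC3)c12`: 12 ug/mL
- compound 2 `COc1c(N2CCN(C)CC2)c(F)cc2c(=O)c(C(=O)N/N=C\c3cccc(O)c3)cn(C3CC3)c12`: 3.4 ug/mL

Of these two, compound 2 holds the lower number, 3.4 ug/mL, and is the stronger inhibitor in this assay. The next compound is compound 3 `COc1c(N2CCN(C)CC2)c(F)cc2c(=O)c(C(=O)N/N=C\c3cccc(C)c3)cn(C3CC3)c12`, with methyl in place of hydroxy on an aromatic carbon, meta to a large group: methyl in place of hydroxy on an aromatic carbon.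

Among the measured compounds shown here, only one measured step is available, a 3.5-fold lower number from compound 1 to compound 2 (0.55 log units; beyond the scatter). For the measured compounds named here, it bears on this change only loosely, since it replaces 5-bromo-2-hydroxyphenyl with 3-hydroxyphenyl, and no measured compound lacks the hydroxy. Its modest size gives a rough scale, while the direction for the new change remains unmeasured. With compound 2 already at the low end at 3.4 ug/mL, a small move toward a higher number is expected: a 1.5-fold higher number from compound 2 to compound 3 (0.17 log units; within the scatter). Compound 3 is estimated at 5 ug/mL, within an expected range of 2 ug/mL to 13 ug/mL.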

Compound 3, half-maximal inhibitory concentration: 10 ug/mL
For compound 3 the middle estimate is 2.0-fold (0.30 log units) below the measured one, and the stated range covers the measured number.
By their numbers in this assay, from the lowest: compound 2; then compounds 3 and 1 (each within the scatter of the next).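

In this assay, this step isolates the hydroxy on the aromatic carbon meta to a large group, and replacing it with methyl gives a change beyond the scatter (a 2.9-fold higher number from compound 2 to compound 3 (0.47 log units; beyond the scatter)). The lower number of compound 2 therefore depends on the hydroxy within the 3-substituted phenyl series, a point that the earlier comparison could not separate from the other differences between compound 1 and compound 2. The step between the other two compounds lies within the scatter (a 1.2-fold lower number from compound 1 to compound 3 (0.08 log units; within the scatter)), so 3-methylphenyl and 5-bromo-2-hydroxyphenyl cannot be told apart here, and nothing available explains the effect of the hydroxy.

As far as these compounds go, it remains open whether the hydroxy itself is required at this place, or whether an amine, a methoxy or a carboxylic acid would hold the number of compound 2. The compounds shown also leave open how a single halogen such as fluorine or chlorine would read on this carbon.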